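From an Aryl Substituent to Bromine: What to Expect

This account rests on a few compounds, and the source may have more. Where it says the series, first, only, none or still open, it means among the compounds named here.

Of the compounds shown here, two built on the same core have been tested in an assay on CHO cells for displacement of a labelled ligand from adenosine receptor A3 (Homo sapiens), read by scintillation counting, tested at 10 uM; on this read-out higher numbers stand for more inhibition at the one concentration tested (going by the name of the read-out) and lower numbers for less inhibition. Compound 1 `Cc1ccccc1-c1sc(N)c(C(=O)c2ccc(Cl)cc2)c1CC(C)(C)C` gives 1%. Compound 2 `CC(C)c1ccc(-c2sc(N)c(C(=O)c3ccc(Cl)cc3)c2CC(C)(C)C)cc1` gives 1%. The only structural difference between them is a 4-isopropylphenyl in place of a 2-methylphenyl on an aromatic carbon, and the step of no change at the digits printed from compound 1 to compound 2 (within the scatter) shows this change to be without effect. Compound 2 therefore stands level with compound 1 at the digits shown, and neither displaces the labelled ligand to any notable degree.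

Compound 3 `CC(C)(C)Cc1c(Br)sc(N)c1C(=O)c1ccc(Cl)cc1` has not yet been measured. Relative to compound 2 it carries bromo in place of 4-isopropylphenyl on an aromatic carbon. Among the compounds with values here, this is a larger alteration than the one between compounds 1 and 2: a six-membered aromatic ring of carbon only leaves and a bromo enters at the same aromatic carbon. Within the data shown here, the one measured step bears on it only loosely, since it exchanged one aromatic substituent for another; it was flat and gives no sign that this position controls inhibition. The expectation for compound 3 is a step of a number 2 percentage points higher from compound 2 to compound 3 (within the scatter), nothing beyond the scatter. Compound 3 is estimated at 3%, with a likely range from -8% to 20%.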

Compound 3, a percentage reported as inhibition, at one concentration (the size of the read-out at that concentration, not a potency): 1%
Estimate against measurement, compound 3: 2 percentage points above, within the range that was stated.
By their numbers in this assay, from the lowest: compounds 1, 2 and 3 (each within the scatter of the next).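

Swapping the 4-isopropylphenyl for a bromo gives no change at the digits printed from compound 2 to compound 3 (within the scatter) in this assay and swapping the 2-methylphenyl for the same bromo gives no change at the digits printed from compound 1 to compound 3 (within the scatter) on this read-out. The earlier pair only exchanged one six-membered aromatic ring of carbon only for another, whereas these steps remove that ring altogether, with 9 heavy atoms leaving and 1 entering on the aromatic carbon next to the ring sulfur, and the read-out stays flat among these three compounds. Nothing at hand explains this flat result.

All three compounds share the neopentyl group, the amino group and the (4-chlorophenyl)carbonyl group, so the compounds shown cannot tell whether these groups have any bearing on the low inhibition seen here. Nor do they show whether a group of a different kind on the same aromatic carbon, such as an amine, a carboxylic acid or a longer chain, would give a reading beyond the scatter, since neither of the two aryl groups nor the bromo has moved the number at all.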